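A Phenyl Added to the Ketone-Bearing Five-Membered Ring

A few compounds are considered here, and "the series" means these few. Any claim that something is new, unique, unknown or untested is made for them only; others in the source may bear on it.

Compound 1: `O=C(CCCCCc1ccccc1)c1nc2ccccc2s1`, > 10000 nM
Compound 2: `O=C(CCCCCCc1ccccc1)c1nncs1`, > 10000 nM

Both measured compounds were tested in an assay on HEK-293T cells for inhibition of diacylglycerol lipase-alpha (Homo sapiens), read by colorimetric assay; a lower number here means a stronger inhibitor, a higher number a weaker inhibitor. Compound 1 gives only a limit of the assay, > 10000 nM. Compound 2 likewise gives only a limit, > 10000 nM. Compound 2 therefore stands at the limit of > 10000 nM in this assay, at which 2 of the 2 values shown sit. Compound 3, `O=C(CCCCCCc1ccccc1)c1nnc(-c2ccccc2)s1`, differs from compound 2 by phenyl in place of hydrogen on an aromatic carbon. Within the data shown here, no step between measured compounds is available, so the size of the change in this assay is open; a modest step toward a stronger inhibitor, or none beyond the scatter, is expected. For compound 3 the expected value is 8000 nM, between 1000 nM and 30000 nM. This is expected to mean a step of an at least 1.2-fold lower number from compound 2 to compound 3 (0.09 log units; that floor lies within the scatter).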

Compound 3, half-maximal inhibitory concentration: > 10000 nM
Compound 3: only a limit was reported; the forecaster's own chance of this, stated with the estimate: 55%; middle value at least 1.2-fold (0.09 log units) from the limit.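

Among these compounds, compound 3 also gives only a limit in this assay, > 10000 nM, and compound 2 is a limit too, so no step from compound 2 to compound 3 can be read. The compounds shown leave open whether phenyl in place of hydrogen changes inhibition at all, as every value sits at the same limit: the limit of > 10000 nM in this assay, at which 3 of the 3 values shown sit.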